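Silyl-to-acetyl exchange on the shared core

A few compounds are considered here, and "the series" means these few. Any claim that something is new, unique, unknown or untested is made for them only; others in the source may bear on it.

compound 1 `COc1ccc(C2=C(c3cc(OC)c(OC)c(OC)c3)C(=O)C(O[SiH2]C(C)(C)C)C2)cc1OC(C)C` — 7 ug/mL
compound 2 `COCOc1cc(C2=C(c3cc(OC)c(OC)c(OC)c3)C(=O)CC2O[SiH2]C(C)(C)C)ccc1OC` — 32 ug/mL

In an ADME assay on L132 cells (Homo sapiens) for cytotoxicity, read by MTT assay, with a stated time of 72 h (on this read-out higher numbers stand for weaker inhibition and lower numbers for stronger inhibition), compound 1 gives 7 ug/mL, the lowest of the two numbers. Compound 2 gives 32 ug/mL, a higher number that lies beyond the scatter. Compound 3 `COc1ccc(C2=C(c3cc(OC)c(OC)c(OC)c3)C(=O)C(OC(C)=O)C2)cc1OC(C)C` has not yet been measured. It differs from compound 1 in one place: a group of 3 heavy atoms (2 carbon, 1 oxygen; no ring) in place of a group of 5 heavy atoms (4 carbon, 1 silicon; no ring), on an oxygen on a saturated carbon. Among the compounds with values here, no pair of measured compounds shows this change, so its direction is not fixed by the data. The step of a 1.4-fold higher number from compound 1 to compound 3 (0.15 log units; within the scatter) is expected to be small, toward a somewhat higher number, near the edge of the scatter. Compound 3 is estimated at 10 ug/mL, within 3 ug/mL to 30 ug/mL.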

Compound 3, half-maximal inhibitory concentration: > 100 ug/mL
Compound 3 was reported as a limit; the forecaster's own chance of this, stated with the estimate: 5%; middle value at least 10-fold (1.00 log units) away from the limit.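

In this assay, acetyl in place of the group of 5 heavy atoms (4 carbon, 1 silicon), on an oxygen on a saturated carbon, gives an at least 14-fold higher number from compound 1 to compound 3 (1.15 log units; beyond the scatter). Within the data shown here, the number at this position therefore depends strongly on the group the oxygen carries, which compound 1 and compound 2 could not show, as no step links them. Compound 3 stands only as a limit of the assay: the limit of > 100 ug/mL in this assay, at which 1 of the 3 values shown sits.

Open, going by these compounds, is how a free hydroxyl, a longer ester such as butyryl, or a methyl ether on this oxygen would read. Also open, on these data alone, is whether acetyl at the other oxygen-bearing placement, that of compound 2, reads the same way.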